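The source may hold more compounds than are shown below. What is called first, only, known or untested is meant among the compounds shown, and "the series" means these compounds.

Measured compounds:
- compound 1 `CCOC(=O)c1cc2cc(OCCCC3CCN(Cc4ccccc4)CC3)ccc2n1C`; in an assay on isolated protein for inhibition of Amine oxidase [flavin-containing] A (Homo sapiens), read by fluorescence, with stated times of 30 min and 1 h (a higher number here means a weaker inhibitor, a lower number a stronger inhibitor), compound 1 gives 1530 nM
- compound 2 `Cn1c(C(=O)O)cc2cc(OCCCC3CCN(Cc4ccccc4)CC3)ccc21`; in this assay compound 2 gives > 100000 nM, a limit of the assay
- compound 3 `Cn1c(C(=O)Nc2ccccc2)cc2cc(OCCCC3CCN(Cc4ccccc4)CC3)ccc21`; in this assay compound 3 gives > 100000 nM, a limit of the assay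

Compound 3 thus stands at the upper limit, sharing it with compound 2; only compound 1 gives a number. Compound 4 `Cn1c(C(=O)N2CCOCC2)cc2cc(OCCCC3CCN(Cc4ccccc4)CC3)ccc21` differs from compound 3 by morpholin-4-yl in place of anilino on a carbonyl carbon. The step that bears on it is an at least 65-fold higher number from compound 1 to compound 3 (1.81 log units; beyond the scatter), where an amide replaced the ester; a step that the two limits leave unreadable from compound 2 to compound 3 cannot be read, as the limit of > 100000 nM in this assay, at which 2 of the 3 values shown sit, shows. Within the data shown here, with a second amide and no step from one amide to another measured, compound 4 is expected to remain weak, and the expected at least 1.6-fold lower number from compound 3 to compound 4 (0.22 log units; that floor lies within the scatter) is likewise unreadable against the limit. Compound 4 is estimated at 60000 nM, within 5000 nM to 300000 nM.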

Compound 4, half-maximal inhibitory concentration: > 100000 nM
Compound 4 was reported as a limit; the forecaster's own chance of this, stated with the estimate: 60%; middle value at least 1.6-fold (0.22 log units) away from the limit.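

Morpholin-4-yl in place of ethoxy on a carbonyl carbon gives an at least 65-fold higher number from compound 1 to compound 4 (1.81 log units; beyond the scatter). In this assay compound 4 gives > 100000 nM, a limit of the assay. The anilino and morpholin-4-yl amides thus both sit at this limit, with or without the amide hydrogen, and the steps among compound 2, compound 3 and compound 4 cannot be read: the limit of > 100000 nM in this assay, at which 3 of the 4 values shown sit.

As far as these compounds go, only compound 1 gives a number, so it remains open how much of that reading depends on the ethyl ester itself. A methyl ester, a longer-chain ester or a ketone on this carbonyl carbon would test that.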